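This account rests on a few compounds, and the source may have more. Where it says the series, first, only, none or still open, it means among the compounds named here.

Measured in a functional assay on A549 cells (Homo sapiens) for antiproliferative activity, read by MTT assay; a lower number here means a stronger inhibitor, a higher number a weaker inhibitor:
- compound 1 `Cn1c(=O)c(=O)n(C2CCCC2)c2nc(N/N=C/c3ccc(Cl)cc3)ncc21`: 6890 nM
- compound 2 `Cn1c(=O)c(=O)n(C2CCCC2)c2nc(N/N=C/c3cccs3)ncc21`: > 100000 nM (a limit)

Compound 2 has only a limit, > 100000 nM, and no exact number. Compound 3 `COc1ccc(/C=N/Nc2ncc3c(n2)n(C2CCCC2)c(=O)c(=O)n3C)cc1` differs from it at one place: 4-methoxyphenyl in place of thiophen-2-yl on a carbon with a double bond to nitrogen. This puts 4-methoxyphenyl in place of thiophen-2-yl on a carbon with a double bond to nitrogen. Going by the values given here, one measured step bears on this change, the large at least 14-fold higher number from compound 1 to compound 2 (1.16 log units; beyond the scatter). From the compounds shown here alone, that step introduced thiophen-2-yl in place of 4-chlorophenyl, so going back to a six-membered aromatic ring of carbon only should lower the number in this assay, though 4-methoxyphenyl itself is untested. The expected change is an at least 6.6-fold lower number from compound 2 to compound 3 (0.82 log units; beyond the scatter). For compound 3 the estimated value is 15000 nM, with an expected range of 4000 nM to 60000 nM.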

Compound 3, half-maximal inhibitory concentration: > 100000 nM
Compound 3: only a limit was reported; the forecaster's own chance of this, stated with the estimate: 15%; at least 6.6-fold (0.82 log units) between middle value and limit.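

Compound 3 gives > 100000 nM, which is a limit and not an exact number. Methoxy in place of chloro on an aromatic carbon brings an at least 14-fold higher number from compound 1 to compound 3 (1.16 log units; beyond the scatter), so a six-membered aromatic ring of carbon only does not by itself keep the number low, and the group on that ring matters. The step between compound 2 and compound 3 cannot be read because both values are limits: the limit of > 100000 nM in this assay, at which 2 of the 3 values shown sit.

From the compounds shown here alone, whether chloro is special or other groups on that ring, such as fluoro or an amine, would also give a measurable number stays open. Going by these compounds, the true order of compound 2 and compound 3 also stays open.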